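A few compounds are considered here, and "the series" means these few. Any claim that something is new, unique, unknown or untested is made for them only; others in the source may bear on it.

Compound 1 `COc1ccc(NC(=O)CNCCCC(=O)Nc2ccccc2N)cc1` was examined in a functional assay on HCT-116 cells (Homo sapiens) for inhibition, read by MTT assay, with a stated time of 2 days; on this read-out lower numbers stand for higher toxicity in this test and higher numbers for lower toxicity in this test. In this assay compound 1 reaches only the limit of the assay, > 100000 nM, and no true number. Compound 2 `Nc1ccccc1NC(=O)c1ccc(NCC(=O)Nc2ccc(Cl)cc2)cc1` likewise gives in this assay only the limit > 100000 nM. Both results therefore sit at the limit of > 100000 nM in this assay, at which 2 of the 2 values shown sit. Compound 3 `Nc1ccccc1NC(=O)CCCNCC(=O)Nc1cccc(Cl)c1` has not yet been measured; it differs from compound 1 by 3-chlorophenyl in place of 4-methoxyphenyl on an amide-type nitrogen. Within the data shown here, with no measured step between compounds to draw on, no change beyond the usual scatter is expected in this assay. Compound 3 is expected to give about 150000 nM, within 50000 nM to 500000 nM. The step this implies is estimated as a step that the limit leaves unreadable from compound 1 to compound 3.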

Compound 3, concentration lethal to 50% of the cells: > 100000 nM
Compound 3: only a limit was reported; the forecaster's own chance of this, stated with the estimate: 80%; the middle value lies beyond the limit too.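

Among these compounds, compound 1 and compound 3 both give only a limit, so no step between them can be read: the limit of > 100000 nM in this assay, at which 3 of the 3 values shown sit. The compounds shown leave open whether 3-chlorophenyl and 4-methoxyphenyl differ at all in this assay.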